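A few compounds are considered here, and "the series" means these few. Any claim that something is new, unique, unknown or untested is made for them only; others in the source may bear on it.

Three compounds have been measured so far in an ADME assay on RAW264.7 cells (Mus musculus) for cytotoxicity, read by MTT assay, with a stated time of 72 h, tested at 50 ug/mL; a lower number here means less inhibition, a higher number more inhibition at the concentration tested (going by the name of the read-out):

compound 1 `CCOC(=O)c1nc2cc(Cl)ccc2s1` gives 37.4%
compound 2 `COc1ccc(N2CCN(C(=O)c3nc4cc(C(F)(F)F)ccc4s3)CC2)cc1` gives 19.4%
compound 3 `COc1ccccc1N1CCN(C(=O)c2nc3cc(Cl)ccc3s2)CC1` gives 63.4%

Compound 2 stands lowest of the three numbers in this assay. Compound 1 is nearest to it, higher by a gap beyond the usual scatter, and compound 3 is furthest, higher by a gap that is also beyond the scatter. Compound 4 `O=C(c1nc2cc(C(F)(F)F)ccc2s1)N1CCN(c2ccncc2)CC1` has not yet been measured in this assay. Its structure differs from that of compound 2 in one place: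

pyridin-4-yl in place of 4-methoxyphenyl on an amine nitrogen in a ring

Among the compounds with values here, no two measured compounds differ in a single place, so there is no measured step that shows the size of such a swap; the three values show only that compound 2, carrying the 4-methoxyphenyl group, sits lowest. The step in this assay is therefore expected to be small, either within the scatter or a modest rise. Compound 4 is expected to give about 26%, within a range from 8% to 46%, which means an expected step of a number 6.6 percentage points higher from compound 2 to compound 4 (within the scatter).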

Compound 4, a percentage reported as inhibition, at one concentration (the size of the read-out at that concentration, not a potency): 17.5%
The estimate for compound 4 lay 8.5 percentage points above the measured number, and the stated range covers the measured number.
By their numbers in this assay, from the lowest: compounds 4 and 2 (each within the scatter of the next); then compound 1; then compound 3.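

In this assay, within the data shown here, the swap of 4-methoxyphenyl for pyridin-4-yl on an amine nitrogen in a ring gives the first single-place step, and that step is a number 1.9 percentage points lower from compound 2 to compound 4 (within the scatter). At this position, then, an aromatic ring of carbon only bearing a methoxy group and an aromatic ring with one hetero atom cannot be told apart in this read-out, although the incoming group has fewer heavy atoms. Nothing measured here bears on why the two groups read alike.

From the compounds shown here alone, whether this flat response extends to a different group on the same nitrogen, such as a benzyl group, or a phenyl ring carrying a carboxylic acid, remains open. The compounds shown also do not tie the value of compound 3, 63.4%, to any single place in its structure.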